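Fluoropyridinyl in place of methoxypyridinyl on the sulfonyl

The source may hold more compounds than are shown below. What is called first, only, known or untested is meant among the compounds shown, and "the series" means these compounds.

Compound 1 `CNCc1cc(-c2cccnc2F)n(S(=O)(=O)c2ccsc2)c1`: 98%
Compound 2 `CNCc1cn(S(=O)(=O)c2ccccn2)c(-c2cccnc2F)c1F`: 95%
Compound 3 `CNCc1cn(S(=O)(=O)c2cc(OC)ccn2)c(-c2cccnc2F)c1F`: 95%

In a functional assay on the whole organism (strain Jcl:Sprague-Dawley) for inhibition, with Rattus norvegicus as the target, with stated times of 3 min and 3 h, at a dose of 1 mg/kg by the intravenous route (a higher number here means more inhibition at the dose given (going by the name of the read-out), a lower number less inhibition), compound 3 stands level with compound 2 at the digits shown, the two together the lowest of the three numbers, while compound 1 sits higher by a gap that lies within the scatter. Going by the values given here, the one measured step, no change at the digits printed from compound 2 to compound 3 (within the scatter), bears on the present change as another alteration of the ring on the sulfonyl sulfur and was flat. Compound 4 `CNCc1cn(S(=O)(=O)c2ccc(F)cn2)c(-c2cccnc2F)c1F` differs from compound 3 by 5-fluoropyridin-2-yl in place of 4-methoxypyridin-2-yl on a sulfonyl sulfur. Because no change at the digits printed from compound 2 to compound 3 (within the scatter) showed nothing beyond the scatter, compound 4 is expected to move by no change at the digits printed from compound 3 to compound 4 (within the scatter) in this assay, that is, no step beyond the scatter. Compound 4 is estimated at 95%, between 87% and 99%.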

Compound 4, a percentage reported as inhibition, in the whole organism at one dose (the size of the read-out at that dose, not a potency): 87%
The estimate for compound 4 lay 8 percentage points above the measured number; measured number inside the range.
By their numbers in this assay, from the lowest: compounds 4, 2, 3 and 1 (each within the scatter of the next, the first and the last beyond it).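

In this assay, 5-fluoropyridin-2-yl on the sulfonyl sulfur gave a number 8 percentage points lower from compound 3 to compound 4 (within the scatter) and fluoro in place of hydrogen on an aromatic carbon gave a number 8 percentage points lower from compound 2 to compound 4 (within the scatter) so a fluoro substituent on this ring, like the methoxy before it, produced no step beyond the scatter. This position has therefore now accepted two different substituents without a step beyond the scatter. No available evidence accounts for these numbers.

On these data alone, whether an amine or a carboxylic acid on this ring would give a step beyond the scatter remains open. So does whether a longer alkoxy chain in place of methoxy would.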